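A dichlorophenyl thioether at the cytotoxicity limit

The compounds below may be only part of what the source reports. "The series", "measured", "known", "first", "only" and "open" are said of these compounds alone.

Compound 3 `OB1OCc2ccc(-n3cc(Sc4ccc(O)cc4)c4ccccc43)cc21` carries a (4-hydroxyphenyl)sulfanyl group on the shared core. In an ADME assay on L929 cells (Mus musculus) for cytotoxicity, read by resazurin assay, with a stated time of 72 h (on this read-out lower numbers stand for stronger inhibition and higher numbers for weaker inhibition), compound 3 gives only a limit, > 10 ug/mL. Compound 1 `OB1OCc2ccc(-n3ccc4ccccc43)cc21`, with hydrogen in that place, also gives only a limit in this assay, namely > 10 ug/mL. Compound 2 `COc1ccc(Sc2cn(-c3ccc4c(c3)B(O)OC4)c3ccccc23)cc1`, the (4-methoxyphenyl)sulfanyl analogue, likewise gives only a limit, > 10 ug/mL. The step that the two limits leave unreadable from compound 1 to compound 3, the step that the two limits leave unreadable from compound 1 to compound 2 and the step that the two limits leave unreadable from compound 2 to compound 3 are all unreadable, because every value shown sits at the limit of > 10 ug/mL in this assay, at which 3 of the 3 values shown sit.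

Compound 4 `OB1OCc2ccc(-n3cc(Sc4ccc(Cl)c(Cl)c4)c4ccccc43)cc21` differs from compound 3 by 3,4-dichlorophenyl in place of 4-hydroxyphenyl on a sulfur. Among the compounds with values here, none of the measured steps is readable, so nothing in this assay tells the size or direction of this change, and compound 3 itself is known only as a limit. Compound 4 is therefore expected to remain near that same limit, with an estimated step of a number no higher from compound 3 to compound 4 (the limit leaves the size open). The estimate for compound 4 in this assay is 10 ug/mL, with an expected range from 3 ug/mL to 30 ug/mL.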

Compound 4, half-maximal inhibitory concentration: > 10 ug/mL
Compound 4: only a limit was reported; the forecaster's own chance of this, stated with the estimate: 60%; the middle value lies on the limit itself.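

In this assay compound 4 gives only a limit, > 10 ug/mL. Its steps from compound 1, compound 2 and compound 3 therefore cannot be read: the limit of > 10 ug/mL in this assay, at which 4 of the 4 values shown sit.

The compounds shown leave open whether any of these sulfanyl groups changes cytotoxicity, and in which direction.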